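The source may hold more compounds than are shown below. What is called first, only, known or untested is meant among the compounds shown, and "the series" means these compounds.

Measured compounds in a functional assay on HepG2 cells (Homo sapiens) for cytotoxicity, read by MTT assay, with a stated time of 72 h; on this read-out higher numbers stand for weaker inhibition and lower numbers for stronger inhibition:
- compound 1, `Cn1ccc2c(Oc3ccc(NC(=O)c4nn(-c5ccccc5)ccc4=O)cc3)ccnc21`: 56200 nM
- compound 2, `Cn1ccc2c(Oc3ccc(NC(=O)c4nn(-c5ccc(Cl)cc5)ccc4=O)cc3F)ccnc21`: > 60000 nM, a limit of the assay
- compound 3, `Cn1ccc2c(Oc3ccc(NC(=O)c4nn(-c5ccccc5)ccc4=O)cc3F)ccnc21`: > 60000 nM, a limit of the assay

Compound 3 stands at the top of the measured range in this assay, with only a limit and no number, as the limit of > 60000 nM in this assay, at which 2 of the 3 values shown sit, records. Two measured steps lead into it. From compound 1 the fluoro addition gives an at least 1.0-fold higher number from compound 1 to compound 3 (0.02 log units; that floor lies within the scatter). The chloro removal gives a step that the two limits leave unreadable from compound 2 to compound 3, both ends being limits. Neither step reads as a change beyond the scatter.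

Compound 4, `Cn1ccc2c(Oc3ccc(NC(=O)c4nn(-c5ccc(Cl)c(C(F)(F)F)c5)ccc4=O)cc3F)ccnc21`, differs from compound 3 by 4-chloro-3-(trifluoromethyl)phenyl in place of phenyl on an aromatic nitrogen. Among the measured compounds shown here, no measured step varies this ring in a way that yields two numbers; compound 2, which carries chloro on the same ring, sits at a limit, and compound 1 with the plain phenyl gives a number close to the limit. The step of a number no higher from compound 3 to compound 4 (the limit leaves the size open) is therefore expected to lie within the scatter, with compound 4 most likely reported again as a limit. Compound 4 is estimated at 60000 nM, within 20000 nM to 200000 nM.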

Compound 4, half-maximal inhibitory concentration: 13500 nM
For compound 4 the middle estimate is 4.4-fold (0.65 log units) above the measured one; the measured number lies below the stated range.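

In this assay, among the compounds shown here, the ring on the aromatic nitrogen is the first place where a change reads beyond the scatter: 4-chloro-3-(trifluoromethyl)phenyl in place of phenyl gives an at least 4.4-fold lower number from compound 3 to compound 4 (0.64 log units; beyond the scatter). Trifluoromethyl in place of hydrogen on that ring gives an at least 4.4-fold lower number from compound 2 to compound 4 (0.64 log units; beyond the scatter), whereas chloro alone leaves compound 2 at a limit, so among these compounds a measured number on a chloro-bearing ring appears only with trifluoromethyl also present. Both steps start from a limit, so each gives only a floor and the full size stays unknown: the limit of > 60000 nM in this assay, at which 2 of the 4 values shown sit.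

On these data alone, whether trifluoromethyl without chloro on the phenyl gives a similar step remains open. Also open, as far as these compounds go, is how this ring behaves with other groups at the same place, such as methoxy, an amine or a carboxylic acid.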